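The source may hold more compounds than are shown below. What is called first, only, known or untested is meant among the compounds shown, and "the series" means these compounds.

Working notes on the series.

Compound 1 `Cc1ccc(OC[C@@H]2[C@H]3CC[C@H](c4nc(C(=O)O)cs4)O[C@H]3C[C@H]2O)cc1` opens the set and is read in an assay on HEK293 cells for agonist activity at prostaglandin E2 receptor EP2 subtype (Homo sapiens), read by a beta-galactosidase reporter and beta-arrestin recruitment, with a stated time of 90 min; on this read-out higher numbers stand for an effect only at larger amounts of compound and lower numbers for an effect already at smaller amounts. In this assay compound 1 gives > 10000 nM, which is a limit of the assay and not a number. Compound 2 `O=C(O)c1csc([C@H]2CC[C@@H]3[C@@H](COc4cccc(F)c4)[C@H](O)C[C@@H]3O2)n1` carries a 3-fluorophenyl in place of the 4-methylphenyl on the oxygen on a saturated carbon. In this assay compound 2 gives > 10000 nM, again a limit. Compound 3 `O=C(O)c1csc([C@H]2CC[C@@H]3[C@@H](COc4ccc(F)cc4)[C@H](O)C[C@@H]3O2)n1` carries the 4-fluorophenyl there. In this assay compound 3 gives > 10000 nM, likewise a limit. Compound 3 thus stands only at a limit, as do the two other values shown; the steps a step that the two limits leave unreadable from compound 1 to compound 2, a step that the two limits leave unreadable from compound 1 to compound 3 and a step that the two limits leave unreadable from compound 2 to compound 3 cannot be sized, since (the limit of > 10000 nM in this assay, at which 3 of the 3 values shown sit).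

Compound 4 `O=C(O)c1csc([C@H]2CC[C@@H]3[C@@H](COc4ccccc4Cl)[C@H](O)C[C@@H]3O2)n1` differs from compound 3 by 2-chlorophenyl in place of 4-fluorophenyl on an oxygen on a saturated carbon. For the measured compounds named here, no measured step is readable, so nothing bears on the size or direction of the change. The step that the limit leaves unreadable from compound 3 to compound 4 is therefore expected to stay within the scatter. Compound 4 is estimated at 15000 nM in this assay, within 5000 nM to 50000 nM, most likely reported again only as a limit.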

Compound 4, half-maximal effective concentration: 203 nM
Compound 4: the middle estimate sits 74-fold (1.87 log units) above what was measured; measured number below the stated range.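

On the oxygen on a saturated carbon, 2-chlorophenyl is the only group shown that gives a readable number in this assay, with an at least 49-fold lower number from compound 3 to compound 4 (1.69 log units; beyond the scatter), an at least 49-fold lower number from compound 2 to compound 4 (1.69 log units; beyond the scatter) and an at least 49-fold lower number from compound 1 to compound 4 (1.69 log units; beyond the scatter). This position is therefore not silent: a change of the aryl group alone, with the rest of the structure held, moves the compound off the limit. Each of these steps gives only a minimum size, and the steps among compound 1, compound 2 and compound 3 stay unreadable, because of the limit: the limit of > 10000 nM in this assay, at which 3 of the 4 values shown sit.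

The compounds shown leave open whether the gain follows the chlorine or its place on the ring, as 4-chlorophenyl, 3-chlorophenyl and 2-fluorophenyl are not among them. Whether 2-methylphenyl or 2-methoxyphenyl would also give a readable number is open as well.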